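Growth inhibition of three compounds and one unmeasured trifluoromethyl analogue

This account rests on a few compounds, and the source may have more. Where it says the series, first, only, none or still open, it means among the compounds named here.

Compound 1 (`c1ccc(-c2ccc(-c3ccc(-c4nc5ccccc5[nH]4)cc3)cc2)cc1`): 100000 nM
Compound 2 (`Cc1ccc2[nH]c(-c3ccc(-c4ccc(-c5ccc(N(C)C)cc5)cc4)cc3)nc2c1`): 6240 nM
Compound 3 (`COc1cc(-c2ccc(-c3ccc(-c4nc5cc(C)ccc5[nH]4)cc3)cc2)cc(OC)c1OC`): 170 nM

All three compounds were measured in a functional assay on Gurav cells (Homo sapiens) for inhibition, read by sulforhodamine B assay (on this read-out lower numbers stand for stronger inhibition of growth and higher numbers for weaker inhibition of growth), and compound 1 has the highest number of the three, well beyond the scatter from both of the others. Compound 4 (`FC(F)(F)c1ccc(-c2ccc(-c3ccc(-c4nc5ccccc5[nH]4)cc3)cc2)cc1`) has not yet been measured. It keeps the core of compound 1, but trifluoromethyl stands in place of hydrogen on an aromatic carbon, para to a large group (trifluoromethyl in place of hydrogen on an aromatic carbon), so that phenyl becomes 4-(trifluoromethyl)phenyl.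

Within the data shown here, no two measured compounds differ in one place only, so no measured step shows what a single change does in this assay on its own. Among the measured compounds shown here, the only guide is that compound 2 (6240 nM) and compound 3 (170 nM) both sit lower than compound 1, though each differs from it in more than one place and neither carries trifluoromethyl. A move towards a lower number is therefore expected, but a smaller one than the gap to compound 2. The expected change is a 6.7-fold lower number from compound 1 to compound 4 (0.82 log units; beyond the scatter) and its size is uncertain. For compound 4 the estimated value is 15000 nM with an expected range from 2000 nM to 100000 nM in this measurement.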

Compound 4, concentration for 50% growth inhibition: 39100 nM
The estimate for compound 4 lay 2.6-fold (0.42 log units) below the measured number, and the stated range covers the measured number.
By their numbers in this assay, from the lowest: compound 3; then compound 2; then compound 4; then compound 1.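

In this assay, among these compounds, replacing hydrogen with trifluoromethyl on an aromatic carbon, para to a large group, gives a 2.6-fold lower number from compound 1 to compound 4 (0.41 log units; beyond the scatter), the first single change in this set whose effect can be read on its own. The step lies beyond the scatter but is modest, so turning phenyl into 4-(trifluoromethyl)phenyl at this position, with four heavy atoms entering, improves growth inhibition a little without bringing it to a strong level. No measurement shown here bears on what lies behind this step.

The compounds shown leave open whether a fluorine atom, a nitrile, an amine or a carboxylic acid on the same carbon would give a step of similar size or direction, and whether trifluoromethyl would do the same elsewhere on that ring. They also leave open whether the same change would give a step of similar size when made on compound 2 or compound 3, which carry a methyl group on the core that compound 4 lacks.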